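A few compounds are considered here, and "the series" means these few. Any claim that something is new, unique, unknown or untested is made for them only; others in the source may bear on it.

The three measured compounds share one core, shown in compound 1 `C=C1C[C@]23C[C@@]1(O)CC[C@H]2c1ccc(O)c(C)c1[C@@H]3Cn1cc(-c2ccc(C(F)(F)F)cc2)nn1`, and differ only in the groups attached to it. In a functional assay on A549 cells (Homo sapiens) for cytotoxicity, read by MTT assay, with a stated time of 4 days (on this read-out higher numbers stand for weaker inhibition and lower numbers for stronger inhibition), compound 1 gives 10400 nM. Compound 2 `C=C1C[C@]23C[C@@]1(O)CC[C@H]2c1cc(Br)c(O)c(C)c1[C@@H]3Cn1cc(-c2ccc(OC)cc2)nn1` carries a bromo and a methoxy in place of the trifluoromethyl. In this assay compound 2 gives only a limit, > 20000 nM. Compound 3 `C=C1C[C@]23C[C@@]1(O)CC[C@H]2c1ccc(O)c(C)c1[C@@H]3Cn1cc(-c2ccccc2)nn1` lacks the trifluoromethyl of compound 1 and carries no bromo. In this assay compound 3 likewise gives only a limit, > 20000 nM. Among the compounds with values here, the one measured step, an at least 1.9-fold higher number from compound 1 to compound 3 (0.28 log units; that floor lies within the scatter), rests on a floor that falls within the scatter, so compound 3 stands at the limit at which two of the three measured values sit (the limit of > 20000 nM in this assay, at which 2 of the 3 values shown sit). Compound 4 `C=C1C[C@]23C[C@@]1(O)CC[C@H]2c1cc(Br)c(O)c(C)c1[C@@H]3Cn1cc(-c2ccccc2)nn1` is made from compound 3 by bromo in place of hydrogen on an aromatic carbon. Within the data shown here, no measured pair isolates this change: compound 2, the only other compound carrying a bromo, sits at the limit, and compound 3 already sits there. The step is therefore expected to be a step that the limit leaves unreadable from compound 3 to compound 4, nothing beyond the scatter in this assay, and compound 4 is expected to give only a limit again. Compound 4 is estimated at 25000 nM, with 10000 nM to 60000 nM as its range.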

Compound 4, half-maximal inhibitory concentration: > 20000 nM
Compound 4: only a limit was reported (the forecaster's own chance of this, stated with the estimate: 75%); the middle value lies beyond the limit too.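

Neither the step from compound 3 to compound 4 nor the step from compound 2 to compound 4 can be read, as each pair rests on two limits: the limit of > 20000 nM in this assay, at which 3 of the 4 values shown sit.

The compounds shown leave open whether bromo in place of hydrogen on an aromatic carbon changes the result in this assay at all.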